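This account rests on a few compounds, and the source may have more. Where it says the series, first, only, none or still open, it means among the compounds named here.

Compound 1 `O=[N+]([O-])c1cc2c(OCCC3CCCCN3)c(-c3ccccc3Cl)c(O)nc2cc1Cl` gives 360 nM in a functional assay on cells (Pituitary gland cell) for antagonist activity at Gonadotropin-releasing hormone receptor (Rattus norvegicus); a lower number here means a stronger inhibitor, a higher number a weaker inhibitor.
Compound 2 `O=[N+]([O-])c1cc2c(OCCC3CCCCN3)c(-c3ccc4ccccc4c3)c(O)nc2cc1Cl` gives 53 nM in this assay.
Compound 3 `O=[N+]([O-])c1cccc(-c2c(O)nc3cc(Cl)c([N+](=O)[O-])cc3c2OCCC2CCCCN2)c1` gives 100 nM in this assay.

Compound 3 stands second highest of the three numbers: its nearest neighbour is reached by a 1.9-fold higher number from compound 2 to compound 3 (0.28 log units; within the scatter) and its furthest by a 3.6-fold lower number from compound 1 to compound 3 (0.56 log units; beyond the scatter). Compound 4 `O=[N+]([O-])c1cc2c(OCCC3CCCCN3)c(-c3cc(Cl)cc(Cl)c3)c(O)nc2cc1Cl` is not yet measured. The change is 3,5-dichlorophenyl in place of 3-nitrophenyl on an aromatic carbon. For the measured compounds named here, no measured step exchanges a 3-nitrophenyl for a dichlorophenyl; the only step joining a chlorophenyl to the 3-nitrophenyl is a 3.6-fold lower number from compound 1 to compound 3 (0.56 log units; beyond the scatter), and a 2-chlorophenyl is not a 3,5-dichlorophenyl. All three aryl variants fall in a narrow band, so a modest step toward higher numbers in this assay, or none beyond the scatter, is expected, a 1.5-fold higher number from compound 3 to compound 4 (0.18 log units; within the scatter). Compound 4 is estimated at 150 nM, range 50 nM to 450 nM.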

Compound 4, half-maximal inhibitory concentration: 24 nM
Beside the measured number, compound 4's estimate is 6.3-fold (0.80 log units) above it; measured number below the stated range.
By their numbers in this assay, from the lowest: compound 4; then compounds 2 and 3 (each within the scatter of the next); then compound 1.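

For the compounds shown here, at this position, ortho to the 2-(piperidin-2-yl)ethoxy group, the aryl choice spans a wider range in this assay than the earlier compounds showed, with 3,5-dichlorophenyl giving a 4.2-fold lower number from compound 3 to compound 4 (0.62 log units; beyond the scatter), a 2.2-fold lower number from compound 2 to compound 4 (0.34 log units; beyond the scatter) and a 15-fold lower number from compound 1 to compound 4 (1.18 log units; beyond the scatter). The 3,5-dichlorophenyl has no hydrogen-bond acceptors where 3-nitrophenyl has two, so these acceptors are not required for the lowest number among these compounds. Nothing measured here accounts for the step.

The last step changes both the number and the placement of chlorine, and these cannot be separated. As far as these compounds go, how 3-chlorophenyl or 3,5-dimethylphenyl would compare at this position remains open.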